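The source may hold more compounds than are shown below. What is called first, only, known or untested is meant among the compounds shown, and "the series" means these compounds.

Working notes on the series. Compound 1 `O=C(c1ccccc1F)N1CC[C@H]1c1nc(-c2cccc(F)c2)no1` returns only a limit in an assay on HEK293 cells for positive allosteric modulation of metabotropic glutamate receptor 5 (Homo sapiens), read by FLIPR (a lower number here means that less compound is needed, a higher number that more compound is needed for the effect), namely > 10000 nM, and the limit of > 10000 nM in this assay, at which 1 of the 3 values shown sits, marks where that value sits. Compound 2 `O=C(c1ccc(F)c(F)c1)N1CC(c2nc(-c3cccc(F)c3)no2)C1` gives 3200 nM in this assay, the higher of the two numbers recorded so far. Compound 3 `CC1CCC(C(=O)N2CC(c3nc(-c4cccc(Cl)c4)no3)C2)CC1` gives 1500 nM in this assay, a lower number than that of compound 2 and beyond the scatter. Compound 4 `CC1CCCCC1C(=O)N1CC(c2nc(-c3cccc(F)c3)no2)C1` has not been measured; it differs from compound 2 by 2-methylcyclohexyl in place of 3,4-difluorophenyl on a carbonyl carbon. Compound 3 also carries a non-aromatic ring on the carbonyl carbon and gives 1500 nM. On that basis a downward step is expected for compound 4, a 1.8-fold lower number from compound 2 to compound 4 (0.25 log units; within the scatter). Compound 4 is estimated to give 1800 nM in this assay, with a range from 600 nM to 5500 nM.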

Compound 4, half-maximal effective concentration: 540 nM
For compound 4 the middle estimate is 3.3-fold (0.52 log units) above the measured one; measured number below the stated range.
By their numbers in this assay, from the lowest: compound 4; then compound 3; then compound 2. At a limit, above all of these: compound 1.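

On the carbonyl carbon, 2-methylcyclohexyl in place of 3,4-difluorophenyl gives a 5.9-fold lower number from compound 2 to compound 4 (0.77 log units; beyond the scatter), so a non-aromatic ring at this position lowers the number beyond the scatter with the rest of the structure unchanged. Compound 3 also carries a non-aromatic ring there, but it differs from compound 2 in more than one place and could not show this. No result shown bears on the reason for the step.

Open, on these data alone, is whether the methyl on the ring matters, as unsubstituted cyclohexyl would show. Also open, as far as these compounds go, is how a piperidine amine or a longer alkyl chain would read on this carbonyl carbon.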